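The compounds below may be only part of what the source reports. "The series", "measured", "known", "first", "only" and "open" are said of these compounds alone.

Measured so far in an assay on isolated protein for inhibition of Aromatase (Homo sapiens), read by fluorescence; a lower number here means a stronger inhibitor, a higher number a weaker inhibitor:

compound 1, `N#Cc1ccc(S(=O)(=O)N2CCCC(Cn3ccnc3)C2)cc1`, gives 36 nM
compound 2, `CS(=O)(=O)c1ccc(S(=O)(=O)N2CCCC(Cn3ccnc3)C2)cc1`, gives 48 nM
compound 3, `O=S(=O)(c1ccc(OC2CCCC2)c(F)c1)N1CCCC(Cn2ccnc2)C1`, gives 22 nM

All three share the same core and differ only in the groups on the outer six-membered ring. Among the three, compound 3 shows the lowest number in this assay; its gap to compound 1 lies within the usual scatter, and only its gap to compound 2 lies beyond it, so compound 3 cannot be called clearly stronger than compound 1.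

The next compound, compound 4, `O=S(=O)(c1ccc(OC2CCCC2)cc1)N1CCCC(Cn2ccnc2)C1`, keeps the cyclopentyloxy group of compound 3 and carries one change: hydrogen in place of fluoro on an aromatic carbon. Among the measured compounds shown here, the only measured step in this set, a 1.3-fold higher number from compound 1 to compound 2 (0.12 log units; within the scatter), concerns a different group at a different place on the ring and stayed within the scatter. For the measured compounds named here, no measured pair tells directly what removing the fluoro does. Going by the values given here, with only that indirect guide, the step of a 1.4-fold higher number from compound 3 to compound 4 (0.13 log units; within the scatter) is expected to fall within the scatter, with no clear direction. Compound 4 is therefore estimated at 30 nM, with a range from 12 nM to 75 nM.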

Compound 4, half-maximal inhibitory concentration: 14 nM
For compound 4 the middle estimate is 2.1-fold (0.33 log units) above the measured one; the range from low to high includes it.
By their numbers in this assay, from the lowest: compounds 4, 3, 1 and 2 (each within the scatter of the next, the first and the last beyond it).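

Taking away the fluoro that sits ortho to the cyclopentyloxy group gives a 1.6-fold lower number from compound 3 to compound 4 (0.20 log units; within the scatter) in this assay, so at this place on the ring, hydrogen and fluoro cannot be told apart and the fluoro is not required for a low number. Compound 4 also allows the cyclopentyloxy group to be compared directly with the groups of the two earlier compounds, with no fluoro involved: the change from methylsulfonyl gives a 3.4-fold lower number from compound 2 to compound 4 (0.54 log units; beyond the scatter) and the change from cyano gives a 2.6-fold lower number from compound 1 to compound 4 (0.41 log units; beyond the scatter), both modest steps but, unlike the step between cyano and methylsulfonyl, beyond the scatter. Nothing available here explains either the lack of a clear fluoro effect or these cyclopentyloxy steps.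

The compounds shown leave open whether another atom at the same place, such as chloro or a methyl group, would shift the number beyond the scatter. They also leave open how far the cyclopentyloxy step can be extended, for instance with a longer chain, an amine or a carboxylic acid in its place.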